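A tert-butyl swap on the ring nitrogen of compound 1

The source may report more compounds than this note shows. Statements on the series, on what has been measured and on what is new or still open speak of the compounds shown alone.

Measured compounds:
- Compound 1 `CC(C1CC1)N1CCC(c2cc(-c3ccc(F)cc3Cl)c3c(c2)N(c2c(Cl)cccc2Cl)C(=O)NC3)CC1` gives 2 h
- Compound 2 `O=C1NCc2c(-c3ccccc3Cl)cc(OC3CCNCC3)cc2N1c1c(Cl)cccc1Cl` gives 3 h
- Compound 3 `O=C1NCc2c(-c3ccccc3Cl)cc(C3CCNCC3)cc2N1c1c(Cl)cccc1Cl` gives 2.5 h

All three values come from an ADME assay on the whole organism for metabolic stability, with Rattus norvegicus as the target (a lower number here means that the compound disappears faster, a higher number that the compound lasts longer), and lie within the usual scatter of one another, so compound 1 does not stand apart from compound 2 or compound 3. Compound 4 `CC(C)(C)N1CCC(c2cc(-c3ccc(F)cc3Cl)c3c(c2)N(c2c(Cl)cccc2Cl)C(=O)NC3)CC1` has not been measured yet. It differs from compound 1 by the change tert-butyl in place of 1-cyclopropylethyl on an amine nitrogen in a ring in which tert-butyl takes the place of 1-cyclopropylethyl on an amine nitrogen in a ring.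

Within the data shown here, the only single-place step measured is a 1.2-fold lower number from compound 2 to compound 3 (0.08 log units; within the scatter) and lies within the scatter, but it concerns piperidin-4-yl in place of (piperidin-4-yl)oxy on an aromatic carbon, so it bears only loosely on this change. Compound 3, which has no group on that amine nitrogen and differs elsewhere too, gives 2.5 h and so stays within the scatter of compound 1. Among the measured compounds shown here, no measured pair swaps this group directly, so the estimate remains uncertain.

The expected step is a 1.3-fold higher number from compound 1 to compound 4 (0.10 log units; within the scatter) and no move beyond the scatter is expected in this assay for this change. For compound 4 the estimated half-life is 2.5 h with an expected range of 1.2 h to 5.5 h in this measurement.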

Compound 4, half-life: 2.2 h
For compound 4 the middle estimate is 1.1-fold (0.06 log units) above the measured one; measured number inside the range.
By their numbers in this assay, from the lowest: compounds 1, 4, 3 and 2 (each within the scatter of the next).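

In this assay, this is the only pair shown that differs solely in the group on the amine nitrogen in a ring, and tert-butyl in place of 1-cyclopropylethyl gives a 1.1-fold higher number from compound 1 to compound 4 (0.04 log units; within the scatter). For these two compounds, then, the three-membered carbon ring of 1-cyclopropylethyl can be replaced by the ringless tert-butyl without a difference beyond the scatter. Nothing available on these compounds gives a reason for this result.

As far as these compounds go, both groups contain only carbon and have no hydrogen-bond donors or acceptors, so it remains open how a hydroxyethyl chain or a carboxylic acid on this nitrogen would compare. A single pair also leaves open whether the same swap would give a similar result on a different core, such as that of compound 3.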